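Swapping a fluorine for an ethyl amide on compound 2

The source may hold more compounds than are shown below. What is called first, only, known or untested is meant among the compounds shown, and "the series" means these compounds.

Of the compounds shown here, three share a core and have been measured in an assay for inhibition of serine/threonine-protein kinase PLK2 (Homo sapiens), read by FRET and Z'-LYTE, with a stated time of 1 h; on this read-out lower numbers stand for stronger inhibition and higher numbers for weaker inhibition. Compound 1 `CCC1C(=O)N(C)c2cnc(Nc3ccc(S(=O)(=O)NCC(C)C)cc3)nc2N1c1ccn(C)n1` gives 311 nM. Compound 3 `CCC1C(=O)N(C)c2cnc(-n3ccc4cc(C(=O)NCC(C)C)ccc43)nc2N1c1ccn(C)n1` gives 159 nM. Compound 2 `CC[C@@H]1C(=O)N(C)c2cnc(-n3ccc4cc(F)ccc43)nc2N1C1CCCC1` gives 969 nM, the highest of the three numbers and therefore the weakest inhibition, with both other compounds lying beyond the usual scatter from it.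

The next compound, compound 4 `CCNC(=O)c1ccc2c(ccn2-c2ncc3c(n2)N(C2CCCC2)[C@H](CC)C(=O)N3C)c1`, keeps the core of compound 2 and changes a single group: ethylcarbamoyl in place of fluoro on an aromatic carbon. Only the group on that aromatic carbon of the fused two-ring system differs; the rest of compound 2 is untouched.

Within the data shown here, no measured pair tells this step directly. Compound 3, which carries a larger carbamoyl group at the same kind of place though on a different core, gives 159 nM, a lower number than compound 2, so a move toward stronger inhibition is expected. The step from compound 2 to compound 4 is estimated as a 2.8-fold lower number from compound 2 to compound 4 (0.44 log units; beyond the scatter), beyond the scatter. Compound 4 is therefore expected to give about 350 nM, within a range from 120 nM to 1000 nM.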

Compound 4, half-maximal inhibitory concentration: 4.88 nM
Beside the measured number, compound 4's estimate is 72-fold (1.86 log units) above it, and the stated range ends above it.
By their numbers in this assay, from the lowest: compound 4; then compounds 3 and 1 (each within the scatter of the next); then compound 2.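

In this assay, the change at this aromatic carbon gives a 200-fold lower number from compound 2 to compound 4 (2.30 log units; beyond the scatter), which shows that one group at this place on the fused two-ring system can move the number a very long way while the rest of compound 2 stays untouched. Fluoro, with one heavy atom and no hydrogen-bond donor or acceptor, leaves, and ethylcarbamoyl, with five heavy atoms, one hydrogen-bond donor and one hydrogen-bond acceptor, enters, so size and hydrogen-bonding counts change together in this single step. No measurement at hand explains the size of this step.

Which part of the ethylcarbamoyl group matters, the amide hydrogen, the carbonyl or the ethyl chain, remains open. A carboxylic acid, a methyl ester or an amide with a longer chain at this aromatic carbon would help to separate these parts.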